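Swapping the aryl group on the hydrazone carbon

The source may hold more compounds than are shown below. What is called first, only, known or untested is meant among the compounds shown, and "the series" means these compounds.

Measured so far:
compound 1 `CN(C)CCn1cnnc1-c1cc(Oc2ccc(NC(=O)N/N=C/c3ccc(O)c(Br)c3)cc2F)ccn1` — 450 nM
compound 2 `Cn1cnnc1-c1cc(Oc2ccc(NC(=O)N/N=C/c3ccccc3)cc2F)ccn1` — 8790 nM

In a functional assay on HT-29 cells (Homo sapiens) for cytotoxicity, read by MTT assay, with a stated time of 72 h (a lower number here means a stronger inhibitor, a higher number a weaker inhibitor), compound 1 gives 450 nM, the lowest of the two numbers. Compound 2 gives 8790 nM, a much higher number that lies beyond the scatter. Compound 3 `COc1cc(/C=N/NC(=O)Nc2ccc(Oc3ccnc(-c4nncn4CCN(C)C)c3)c(F)c2)cc(OC)c1OC` is not yet measured. It differs from compound 1 in one place: 3,4,5-trimethoxyphenyl in place of 3-bromo-4-hydroxyphenyl on a carbon with a double bond to nitrogen. Going by the values given here, no single-change step between measured compounds is available to guide the size, so only a rough expectation is possible. A moderate rise in number, beyond the scatter, is expected as the step of a 3.3-fold higher number from compound 1 to compound 3 (0.52 log units; beyond the scatter). Compound 3 is therefore estimated at 1500 nM, with a range from 400 nM to 6000 nM.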

Compound 3, half-maximal inhibitory concentration: 3620 nM
Compound 3: the middle estimate sits 2.4-fold (0.38 log units) below what was measured, and the stated range covers the measured number.
By their numbers in this assay, from the lowest: compound 1; then compound 3; then compound 2.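

With the rest of the structure held fixed, an 8.0-fold higher number from compound 1 to compound 3 (0.91 log units; beyond the scatter) in this assay when 3,4,5-trimethoxyphenyl replaces 3-bromo-4-hydroxyphenyl on a carbon with a double bond to nitrogen. Going by these compounds alone, this is the first single-change comparison, and it shows that the number responds to the aryl group at this place. Nothing measured here explains the size of this step.

Which part of the 3-bromo-4-hydroxyphenyl group matters remains open, and a 4-hydroxyphenyl or a 3-bromophenyl group would separate the two. Going by these compounds, how an amine or a carboxylic acid on this ring would behave is also open.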